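A few compounds are considered here, and "the series" means these few. Any claim that something is new, unique, unknown or untested is made for them only; others in the source may bear on it.

In a functional assay on MCF7 cells (Homo sapiens) for cytotoxicity, read by MTT assay, with a stated time of 24 h (a higher number here means a weaker inhibitor, a lower number a stronger inhibitor), compound 3 (`CCNc1cc(-c2ccc(NC(=O)Nc3cccc(Cl)c3)cc2F)ccn1`) gives 6940 nM. That lies within the usual scatter of compound 1 (`CCNc1cc(-c2ccc(NC(=O)Nc3ccc(C(F)(F)F)cc3)cc2C)ccn1`), which gives 6870 nM, while compound 2 (`CCNc1cc(-c2ccc(NC(=O)Nc3ccc(C(F)(F)F)cc3)cc2C(F)(F)F)ccn1`) gives a lower 2390 nM. Compound 4 (`CCNc1cc(-c2ccc(NC(=O)Nc3ccc(C(F)(F)F)cc3)cc2F)ccn1`) alters one group of compound 3: 4-(trifluoromethyl)phenyl in place of 3-chlorophenyl on an amide-type nitrogen. Thus 4-(trifluoromethyl)phenyl stands in place of 3-chlorophenyl on an amide-type nitrogen.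

Among the compounds with values here, no measured step makes this exact exchange. The only one available, a 2.9-fold lower number from compound 1 to compound 2 (0.46 log units; beyond the scatter), is modest and concerns a different change, trifluoromethyl in place of methyl on an aromatic carbon. It is still useful, since both of its compounds carry the incoming 4-(trifluoromethyl)phenyl. With that group, compound 2 reaches 2390 nM and compound 1 reaches 6870 nM, so a number for compound 4 somewhere in that span seems likely. The expected change is small and toward a lower number in this assay, and it may not clear the scatter: a 1.7-fold lower number from compound 3 to compound 4 (0.24 log units; within the scatter). The estimated value for compound 4 is 4000 nM, with an expected range of 1800 nM to 9000 nM.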

Compound 4, half-maximal inhibitory concentration: 8020 nM
The estimate for compound 4 lay 2.0-fold (0.30 log units) below the measured number, within the range that was stated.
By their numbers in this assay, from the lowest: compound 2; then compounds 1, 3 and 4 (each within the scatter of the next).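

In this assay, 4-(trifluoromethyl)phenyl in place of 3-chlorophenyl on an amide-type nitrogen gives a 1.2-fold higher number from compound 3 to compound 4 (0.06 log units; within the scatter), so this exchange makes no readable difference with the rest of compound 3 held constant. The new compound also allows a three-way comparison on an aromatic carbon of the shared core: fluoro in place of methyl gives a 1.2-fold higher number from compound 1 to compound 4 (0.07 log units; within the scatter), which cannot be told apart, whereas fluoro in place of trifluoromethyl gives a 3.4-fold higher number from compound 2 to compound 4 (0.53 log units; beyond the scatter), a modest step that sets the trifluoromethyl compound apart from the other two. Nothing available offers an explanation for these results.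

The compounds shown leave open whether trifluoromethyl on that aromatic carbon would give a similar step with 3-chlorophenyl on the amide-type nitrogen. Going by these compounds, how a methoxy group or an amine on that carbon would compare also remains open.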